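The compounds below may be only part of what the source reports. "The series", "measured", "known", "first", "only" and "open" are said of these compounds alone.

Measured compounds:
compound 1, `O=C(Nc1nc(-c2ccccc2)nc2c1nnn2Cc1ccccc1)C1CCCCC1`, 12 nM
compound 2, `Nc1ccc(C(=O)Nc2nc(-c3ccccc3)nc3c2nnn3Cc2ccccc2)cc1`, 7.1 nM
compound 3, `Cc1ccc(C(=O)Nc2nc(-c3ccccc3)nc3c2nnn3Cc2ccccc2)cc1`, 709 nM

In an assay (strain Wistar) for displacement of a labelled ligand from adenosine receptor A1 (Rattus norvegicus), read by scintillation counting (on this read-out higher numbers stand for weaker inhibition and lower numbers for stronger inhibition), compound 1 stands second highest of the three numbers; compound 2 lies nearest, with a 1.7-fold lower number from compound 1 to compound 2 (0.23 log units; within the scatter), while compound 3 lies furthest, with a 59-fold higher number from compound 1 to compound 3 (1.77 log units; beyond the scatter). The unmeasured compound 4, `O=C(Nc1nc(-c2ccccc2)nc2c1nnn2Cc1ccccc1)c1cccc(C(F)(F)F)c1`, differs from compound 1 in one place: 3-(trifluoromethyl)phenyl in place of cyclohexyl on a carbonyl carbon.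

For the measured compounds named here, two measured steps bear on this change, both replacing the cyclohexyl with an aromatic ring on the carbonyl carbon. The step to the 4-aminophenyl stayed within the scatter, whereas the step to the 4-methylphenyl was large. The contrast between those two aryl groups, a 100-fold higher number from compound 2 to compound 3 (2.00 log units; beyond the scatter), shows that the substituent on the aromatic ring decides the outcome. Compound 4 carries a 3-(trifluoromethyl)phenyl with no amino group, so its pattern is expected to follow compound 3 rather than compound 2, giving a step of a 25-fold higher number from compound 1 to compound 4 (1.40 log units; beyond the scatter) in this assay. Compound 4 is therefore estimated at 300 nM, within a range from 60 nM to 1500 nM.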

Compound 4, inhibition constant: 163 nM
Beside the measured number, compound 4's estimate is 1.8-fold (0.26 log units) above it; the measured number falls inside the stated range.
By their numbers in this assay, from the lowest: compounds 2 and 1 (each within the scatter of the next); then compound 4; then compound 3.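

In this assay, a second aryl group without an amino group also gives a higher number than the cyclohexyl, with a 14-fold higher number from compound 1 to compound 4 (1.13 log units; beyond the scatter), so compound 2 is now the only aryl example that goes against this trend among the compounds shown. The aryl groups without an amino group are not equivalent, however: there is a 4.3-fold lower number from compound 3 to compound 4 (0.64 log units; beyond the scatter), a modest step, while the 4-aminophenyl remains well separated, with a 23-fold higher number from compound 2 to compound 4 (1.36 log units; beyond the scatter). Nothing available gives a reason for these differences.

From the compounds shown here alone, it remains open whether the number of compound 2 depends on the amino group alone, or whether a hydroxyl or dimethylamino group on the ring would give a similar result. A 3-aminophenyl or 3-methylphenyl group would also be needed to separate the effect of the group from that of its place on the ring.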